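Amide series: 4-methylphenyl to 3-chlorophenyl

The compounds below may be only part of what the source reports. "The series", "measured", "known", "first", "only" and "open" are said of these compounds alone.

compound 1 `COc1ccc(-c2cnc(NC(=O)c3ccco3)n2C)cc1` gives > 100000 nM
compound 2 `COc1ccc(-c2cnc(NC(=O)c3ccc(C)cc3)n2C)cc1` gives > 100000 nM
compound 3 `COc1ccc(-c2cnc(NC(=O)c3cccc(Cl)c3)n2C)cc1` is not yet measured

In a toxicity assay on THP-1 cells (Homo sapiens) for inhibition (on this read-out lower numbers stand for higher toxicity in this test and higher numbers for lower toxicity in this test), compound 2 gives > 100000 nM, which is a limit and not a number. Compound 1 gives > 100000 nM, also a limit. Compound 3 differs from compound 2 by 3-chlorophenyl in place of 4-methylphenyl on a carbonyl carbon. Among the compounds with values here, the only measured step is a step that the two limits leave unreadable from compound 1 to compound 2, so it offers no size to carry over. No change beyond the scatter is expected in this assay, and another limit is the likeliest report. The expected step is a number no higher from compound 2 to compound 3 (the limit leaves the size open). Compound 3 is estimated at 100000 nM, with an expected range of 40000 nM to 200000 nM.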

Compound 3, half-maximal cytotoxic concentration: > 28000 nM
Compound 3: no number, only a limit (the forecaster's own chance of this, stated with the estimate: 85%); the middle value is on the limit's open side.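

Within the data shown here, compound 1, compound 2 and compound 3 all report limits, not numbers, in this assay, and no step among them can be read. The compounds shown leave open what actual half-maximal cytotoxic concentration any of these amides has.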